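A few compounds are considered here, and "the series" means these few. Any claim that something is new, unique, unknown or untested is made for them only; others in the source may bear on it.

Compound 2 `CCCCCCCCCCc1ccc(-c2noc(CC[C@@H](N)C(=O)O)n2)cc1` is the starting point. Among the measured compounds shown here, in an assay on HeLa cells for inhibition of sphingosine-1-phosphate transporter SPNS2 (Mus musculus), read by LC-MS, tested at 2 uM (on this read-out higher numbers stand for more inhibition at the one concentration tested (going by the name of the read-out) and lower numbers for less inhibition), compound 2 gives 5%, the lowest of the two numbers measured; the only neighbour, compound 1 `CCCCCCCCCCc1ccc(-c2noc([C@H]3CCCN3)n2)cc1`, gives 12%, and the step of a number 7 percentage points lower from compound 1 to compound 2 (within the scatter) lies within the usual scatter. Compound 3 `CCCCCCCCCCc1ccc(-c2noc(CC(O)CN3CCCC3)n2)cc1` has not been measured; it differs from compound 2 by 1-hydroxy-2-(pyrrolidin-1-yl)ethyl in place of 2-amino-2-carboxyethyl on a saturated chain carbon bound to an aromatic carbon.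

For the measured compounds named here, only one measured step bears on this change, and it sits at the same place in the molecule: a number 7 percentage points lower from compound 1 to compound 2 (within the scatter), which exchanges one group for another on the carbon bound to the aromatic ring without moving the number beyond the scatter. With both measured compounds low and nothing pointing upward, the expected step of a number 5 percentage points higher from compound 2 to compound 3 (within the scatter) is essentially none beyond the scatter. Compound 3 is therefore expected to give about 10%, most likely between -5% and 30%.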

Compound 3, a percentage reported as inhibition, at one concentration (the size of the read-out at that concentration, not a potency): 21%
For compound 3 the middle estimate is 11 percentage points below the measured one, within the range that was stated.
By their numbers in this assay, from the lowest: compounds 2, 1 and 3 (each within the scatter of the next, the first and the last beyond it).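

In this assay, the side chain at this place is not indifferent: a number 16 percentage points higher from compound 2 to compound 3 (beyond the scatter) is the one step shown that clears the scatter. The reach of that result is limited, since a number 9 percentage points higher from compound 1 to compound 3 (within the scatter), so 2-hydroxy-3-(pyrrolidin-1-yl)propyl cannot be told apart from pyrrolidin-2-yl, and only compound 2 stands clearly below another compound. Nothing measured here accounts for the step.

The hydroxy group and the pyrrolidine ring enter together as the amino and carboxylic acid groups leave, so the compounds shown do not say which of these parts matters. Also open, on these data alone, is how the number would respond to a piperidine ring in place of the pyrrolidine, or to a dimethylamino group, or to the same side chain without its hydroxy group.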